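A few compounds are considered here, and "the series" means these few. Any claim that something is new, unique, unknown or untested is made for them only; others in the source may bear on it.

Measured in an ADME assay on microsomes from liver (Homo sapiens) for metabolic stability, with a stated time of 60 min, tested at 10 uM; a lower number here means that less of the compound is left, a higher number that more of the compound is left:
- compound 1 `CCCS(=O)(=O)N1CCN(C2(CNC(=O)c3ccccc3C(F)(F)F)CCCCC2)CC1`: 5%
- compound 2 `CCCS(=O)(=O)N1CCN(C2(CNC(=O)c3ccc(OC(F)(F)F)cc3)CCCCC2)CC1`: 11%
- compound 3 `CCCS(=O)(=O)N1CCN(C2(CNC(=O)c3ccc(F)cc3C)CCCCC2)CC1`: 2%

Compound 3 gives 2%, a number that cannot be told apart from those of the other two compounds. Both a number 3 percentage points lower from compound 1 to compound 3 (within the scatter) and a number 9 percentage points lower from compound 2 to compound 3 (within the scatter) stay within the usual scatter.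

Compound 4 `CCCS(=O)(=O)N1CCN(C2(CNC(=O)c3c(OC)cc(F)cc3SC)CCCCC2)CC1` keeps the shared core and carries 4-fluoro-2-methoxy-6-(methylsulfanyl)phenyl in place of 4-fluoro-2-methylphenyl on a carbonyl carbon. Among the compounds with values here, no measured compound carries a methoxy or a methylsulfanyl group, so the data offer no direct test of either.

Within the data shown here, the only relevant evidence comes from the steps that exchange one group for another at this same place. Beyond the two already given, there is a number 6 percentage points higher from compound 1 to compound 2 (within the scatter), and this too stays within the scatter. None of these exchanges moved the number in this assay measurably, and compound 3 starts from 2%. No step beyond the scatter is therefore expected, in either direction.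

The estimated step is a number 3 percentage points higher from compound 3 to compound 4 (within the scatter). Compound 4 is expected to give about 5%, with an estimated range from 1% to 15%.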

Compound 4, percent of the compound remaining: 1%
Beside the measured number, compound 4's estimate is 4 percentage points above it, within the range that was stated.
By their numbers in this assay, from the lowest: compounds 4, 3, 1 and 2 (each within the scatter of the next).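

In this assay, within the data shown here, 4-fluoro-2-methoxy-6-(methylsulfanyl)phenyl on a carbonyl carbon brings a methoxy and a methylsulfanyl group to this place for the first time, and its exchange for 4-fluoro-2-methylphenyl gives a number 1 percentage points lower from compound 3 to compound 4 (within the scatter) in this reading. Set against the other two groups, the same change gives a number 4 percentage points lower from compound 1 to compound 4 (within the scatter) and also a number 10 percentage points lower from compound 2 to compound 4 (within the scatter) here, so even an exchange that adds 2 hydrogen-bond acceptors and raises the count from 8 to 11 heavy atoms leaves all four compounds within the scatter of one another. No measurement shown accounts for this result or tells the contributions of the methoxy and methylsulfanyl groups apart.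

The compounds shown leave open whether anything at this place can separate itself from these four, as every group tested so far is a substituted phenyl, and a carboxylic acid, an aliphatic amine or a pyridine ring on the carbonyl carbon would test that directly. They also leave open what a change away from this place would do, such as replacing the propyl chain on the sulfonyl group with a methyl group or a cyclopropyl ring.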